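This account rests on a few compounds, and the source may have more. Where it says the series, first, only, none or still open, it means among the compounds named here.

Compound 1 `COc1ccc(-c2cc(/C=C/C(=O)c3ccc(N)cc3)[nH]n2)cc1` and compound 2 `COc1ccc(-c2cc(/C=C/C(=O)c3ccc(N)cc3)[nH]n2)cc1OC` were both tested in a functional assay on SR cells (Homo sapiens) for inhibition, read by sulforhodamine B assay, with a stated time of 48 h; on this read-out lower numbers stand for stronger inhibition of growth and higher numbers for weaker inhibition of growth. In this assay compound 1 gives 6090 nM, and compound 2 gives 5310 nM. The two differ in one place, namely (hydrogen in place of methoxy on an aromatic carbon), and the step that this made was a 1.1-fold higher number from compound 2 to compound 1 (0.06 log units; within the scatter), so the two numbers cannot be told apart.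

Compound 3 `COc1cc(C(=O)/C=C/c2cc(-c3cc(OC)c(OC)c(OC)c3)n[nH]2)cc(OC)c1OC` is built on the same core, but how its core differs from that of compound 2 is not broken down here. In this assay compound 3 reaches only a limit of the assay, > 100000 nM; this is the limit of > 100000 nM in this assay, at which 1 of the 3 values shown sits.

Compound 4 `COc1ccc(-c2cc(/C=C/C(=O)c3cc(OC)c(OC)c(OC)c3)[nH]n2)cc1OC` has not yet been measured. It differs from compound 3 by hydrogen in place of methoxy on an aromatic carbon. The surroundings of that place are not word for word those in compound 2, as here the carbon is also meta to a methoxy group, so this is the same kind of change rather than the same change.

Because the earlier step of a 1.1-fold higher number from compound 2 to compound 1 (0.06 log units; within the scatter) stayed within the scatter, the step from compound 3 to compound 4 is expected to be small as well, a number no higher from compound 3 to compound 4 (the limit leaves the size open). Compound 4 is therefore estimated at 100000 nM, with a likely range from 20000 nM to 300000 nM, and it may again return only a limit.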

Compound 4, concentration for total growth inhibition: 2260 nM
Estimate against measurement, compound 4: 44-fold (1.65 log units) above; measured number below the stated range.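

In this assay the same swap of methoxy for hydrogen gave an at least 44-fold lower number from compound 3 to compound 4 (1.64 log units; beyond the scatter), so the result on one core did not predict the result on the other: the same change on two cores in this assay, a 1.1-fold higher number (0.06 log units; within the scatter) from compound 2 to compound 1 and an at least 44-fold lower number (1.64 log units; beyond the scatter) from compound 3 to compound 4, at least 50-fold (1.70 log units) apart, beyond the scatter of two such steps

Compound 3 gives only a limit of the assay and not a number, so the true size of its step to compound 4 stays unknown, and the step could only be larger than printed: the limit of > 100000 nM in this assay, at which 1 of the 4 values shown sits.

These two steps show that this change cannot be carried between the two cores as a fixed amount, but they do not show which feature of the cores sets the difference, or how the change would behave on a third core.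

The compounds shown compare only hydrogen and methoxy at this place, so it remains open how a hydroxyl group, a fluorine atom or an amine would behave there on either core. On these data alone, it also remains open whether the same gap between the two steps would appear in other cell lines.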